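The source may report more compounds than this note shows. Statements on the series, on what has been measured and on what is new or still open speak of the compounds shown alone.

The measured compounds:
compound 1 `CN(C)CCn1cnnc1-c1cc(Oc2ccc(NC(=O)N/N=C/c3ccccc3O[N+](=O)[O-])cc2F)ccn1`, 1270 nM
compound 2 `CN(C)CCn1cnnc1-c1cc(Oc2ccc(NC(=O)N/N=C/c3ccc(O)c(O)c3)cc2F)ccn1`, 1930 nM

In a functional assay on NCI-H460 cells (Homo sapiens) for cytotoxicity, read by MTT assay, with a stated time of 72 h (a higher number here means a weaker inhibitor, a lower number a stronger inhibitor), compound 2 gives 1930 nM. Going by the values given here, compound 1, the only other measured compound, gives 1270 nM in this assay, and the step of a 1.5-fold higher number from compound 1 to compound 2 (0.18 log units; within the scatter) shows that the two numbers lie within the scatter of each other, so no order between them can be claimed.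

Compound 3 `CN(C)CCn1cnnc1-c1cc(Oc2ccc(NC(=O)N/N=C/c3cccc(Cl)c3Cl)cc2F)ccn1` differs from compound 2 in one place: 2,3-dichlorophenyl in place of 3,4-dihydroxyphenyl on a carbon with a double bond to nitrogen. Among the compounds with values here, the one measured step that bears on this change is a 1.5-fold higher number from compound 1 to compound 2 (0.18 log units; within the scatter), which also exchanged the aryl group on the carbon with a double bond to nitrogen and which stayed within the scatter. That step did not involve the 2,3-dichlorophenyl group, so it informs the present change only loosely. No step beyond the scatter is therefore expected in this assay, and the estimated step is a 1.3-fold lower number from compound 2 to compound 3 (0.11 log units; within the scatter). Compound 3 is expected to give about 1500 nM in this assay, with a range from 500 nM to 5000 nM. Within the data shown here, the range is wide; only one indirect step supports the estimate.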

Compound 3, half-maximal inhibitory concentration: 72 nM
Estimate against measurement, compound 3: 21-fold (1.32 log units) above; the measured number lies below the stated range.
By their numbers in this assay, from the lowest: compound 3; then compounds 1 and 2 (each within the scatter of the next).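

Among the compounds shown, the aryl group on the carbon with a double bond to nitrogen now proves able to change the number in this assay by a large margin, with a 27-fold lower number from compound 2 to compound 3 (1.43 log units; beyond the scatter) and an 18-fold lower number from compound 1 to compound 3 (1.25 log units; beyond the scatter), whereas the earlier exchange at this place stayed within the scatter. The 2,3-dichlorophenyl group has the same count of 8 heavy atoms and the same single six-membered aromatic ring of carbon only as the 3,4-dihydroxyphenyl group it replaces, so the large step from compound 2 to compound 3 comes with no change in those counts, while 2 oxygen give way to 2 chlorine and the hydrogen-bond donors and acceptors each go from 2 to 0. No measurement at hand accounts for this difference.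

The compounds shown do not tell whether both chlorine atoms are needed, or whether a phenyl ring carrying a single chlorine, an unsubstituted phenyl, or a phenyl with bromine atoms or methyl groups in place of the chlorines would give a similar number. They also leave open whether the large step depends on the particular places of the chlorine atoms on the ring.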